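The source may hold more compounds than are shown below. What is called first, only, known or untested is meant among the compounds shown, and "the series" means these compounds.

Of the compounds shown here, three that share one core have been tested in a functional assay on A549 cells (Homo sapiens) for inhibition, read by MTT assay, with a stated time of 48 h; on this read-out lower numbers stand for stronger inhibition and higher numbers for weaker inhibition. Compound 1 `CCOC(=O)c1cc(-c2ccccc2)nn1CC(O)COc1ccc(Cl)cc1` gives 59000 nM in this assay. Compound 2 `CCOC(=O)c1cc(-c2ccccc2)nn1CC(O)COc1ccc([N+](=O)[O-])cc1` differs from compound 1 in a single place, (nitro in place of chloro on an aromatic carbon), and compound 2 gives 48000 nM, so that a 1.2-fold lower number from compound 1 to compound 2 (0.09 log units; within the scatter). Compound 3 `CCOC(=O)c1cc(-c2ccc(OC)cc2)nn1CC(O)COc1ccc(Cl)cc1` differs from compound 1 in another place, (methoxy in place of hydrogen on an aromatic carbon), and compound 3 gives 38000 nM, so that a 1.6-fold lower number from compound 1 to compound 3 (0.19 log units; within the scatter). Going by the values given here, these three numbers lie close to one another, and no compound among them can be called the most or the least potent.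

Compound 4 `CCOC(=O)c1cc(-c2ccc(OC)cc2)nn1CC(O)COc1ccc([N+](=O)[O-])cc1` has not yet been measured in this assay. Relative to compound 3 it carries the same change that compound 2 carries relative to compound 1: nitro in place of chloro on an aromatic carbon. The surroundings of this change are described in the same words in both pairs, so it counts as the same change, although the core of compound 3 carries the methoxy in place of hydrogen that the core of compound 1 lacks. Among the compounds with values here, only one measured instance of this change is available, which is a thin basis for any expectation.

A step of about the same size as the earlier one is expected, namely a 1.2-fold lower number from compound 3 to compound 4 (0.07 log units; within the scatter), because the earlier step of a 1.2-fold lower number from compound 1 to compound 2 (0.09 log units; within the scatter) stayed within the scatter. Compound 4 is therefore expected to give about 32000 nM in this assay. The estimate for compound 4 is expected to fall between 15000 nM and 70000 nM.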

Compound 4, half-maximal inhibitory concentration: 44000 nM
The estimate for compound 4 lay 1.4-fold (0.14 log units) below the measured number; the range from low to high includes it.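

On the core of compound 3, which carries the methoxy, nitro in place of chloro gives a 1.2-fold higher number from compound 3 to compound 4 (0.06 log units; within the scatter) in this assay, and the two instances of this change on the two cores agree as far as such small steps can tell: the same change on two cores in this assay, a 1.2-fold lower number (0.09 log units; within the scatter) from compound 1 to compound 2 and a 1.2-fold higher number (0.06 log units; within the scatter) from compound 3 to compound 4, 1.4-fold (0.15 log units) apart, within the scatter of two such steps The other change in the set, methoxy in place of hydrogen, now also has a second instance, a 1.1-fold lower number from compound 2 to compound 4 (0.04 log units; within the scatter), and it too agrees with its first: the same change on two cores in this assay, a 1.6-fold lower number (0.19 log units; within the scatter) from compound 1 to compound 3 and a 1.1-fold lower number (0.04 log units; within the scatter) from compound 2 to compound 4, 1.4-fold (0.15 log units) apart, within the scatter of two such steps This shows that neither change made a step beyond the scatter on either core, but it does not show that either change has a real effect in this assay, nor that a larger effect would carry from one core to another, and the two nitro steps pointing in opposite directions cannot be read as a true difference.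

The compounds shown leave open whether another group in place of the chloro or nitro on the phenoxy ring, such as an amine or a carboxylic acid, would move the number beyond the scatter. They also leave open whether a longer chain in place of the methoxy would do so, and whether any such step would then carry over between cores.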